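From chloro to methyl, starting at compound 3

The source may hold more compounds than are shown below. What is called first, only, known or untested is meant among the compounds shown, and "the series" means these compounds.

Compound 1 `COc1ccc(CN(CCN(C)C)c2ccc(N)cc2)cc1` gives 9.8
Compound 2 `COc1ccc(CN(CCN(C)C)c2ccc(C)cc2)cc1` gives 9.8
Compound 3 `COc1ccc(CN(CCN(C)C)c2ccc(Cl)cn2)cc1` gives 9.5

These three compounds were measured in a physicochemical assay for acid dissociation, and their numbers sit close together. Compound 3 cannot be told apart from the other two, with a number 0.30 log units lower from compound 1 to compound 3 (within the scatter) and a number 0.30 log units lower from compound 2 to compound 3 (within the scatter) as the measured steps.

The next compound, compound 4 `COc1ccc(CN(CCN(C)C)c2ccc(C)cn2)cc1`, has not been measured yet. It has methyl in place of chloro on an aromatic carbon, so 5-chloropyridin-2-yl becomes 5-methylpyridin-2-yl.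

Within the data shown here, no measured step makes exactly this swap, so the evidence is indirect. The nearest case is a number 0.30 log units lower from compound 2 to compound 3 (within the scatter) in this assay, where 5-chloropyridin-2-yl replaces 4-methylphenyl. That step also changes the ring, so it only loosely bears on this swap. The other comparison is no change at the digits printed from compound 1 to compound 2 (within the scatter), where methyl replaces amino on an aromatic carbon. Neither step goes beyond the scatter, so only a small change seems likely here. The expected step is a number 0.10 log units higher from compound 3 to compound 4 (within the scatter) and would be slightly upward at most, within the scatter. Compound 4 is estimated at 9.6 with an expected range from 9.3 to 9.9 in this measurement.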

Compound 4, acid dissociation constant: 9.6
Beside the measured number, compound 4's estimate shows no gap at the digits printed; the range from low to high includes it.
By their numbers in this assay, from the lowest: compounds 3, 4, 1 and 2 (each within the scatter of the next).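

In this assay, among these compounds, this is the first direct test of methyl in place of chloro on an aromatic carbon of a six-membered aromatic ring with 1 nitrogen, two atoms from the ring nitrogen, and it gives a number 0.10 log units higher from compound 3 to compound 4 (within the scatter), so the two groups cannot be told apart at this position. Compound 4 also isolates the ring swap, which the earlier comparison of a chloro-bearing ring with a methyl-bearing one could not do: with methyl kept in both compounds, 5-methylpyridin-2-yl in place of 4-methylphenyl gives a number 0.20 log units lower from compound 2 to compound 4 (within the scatter). The wider swap, 5-methylpyridin-2-yl in place of 4-aminophenyl, changes both the ring and the group on it and gives a number 0.20 log units lower from compound 1 to compound 4 (within the scatter), so none of these three new steps separates the compounds in this measurement.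

Among the compounds shown here, whether a nitrile, a carboxylic acid or a longer chain at this position would shift the number beyond the scatter remains open, since chloro and methyl are the only two groups compared directly here. No information available here explains why these numbers stay so close together.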